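Chain extension on the core: compound 1 to compound 4

A few compounds are considered here, and "the series" means these few. Any claim that something is new, unique, unknown or untested is made for them only; others in the source may bear on it.

Three compounds of the series have been measured in a functional assay on the whole organism with Mus musculus as the target, in the writhing test; a lower number here means that less compound is needed, a higher number that more compound is needed for the effect:

compound 1 `Cc1cc(=O)oc2c1c(C)nn2C`: 11.6 mg/kg
compound 2 `Cc1cc(=O)oc2nn(C)c(C)c12`: 6.09 mg/kg
compound 3 `Cc1cc(O)oc2nncc1-2`: 40.6 mg/kg

Compound 1 sits second highest of the three numbers. Compound 2 gives a number within the usual scatter of that of compound 1, so no order between the two can be read. Among the compounds with values here, compound 3 needs a clearly larger dose than compound 1, beyond the scatter, and since no single-point step connects them, only the two values themselves can be compared.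

The next compound, compound 4 `CCCn1nc(C)c2c(C)cc(=O)oc21`, is compound 1 with one change: ethyl in place of hydrogen on a saturated chain carbon bound to an aromatic nitrogen. Cut one bond further out, the same change reads methyl to propyl. Within the data shown here, no pair of measured compounds differs in one place, so no measured step sets a scale for this change. The expectation is a step from compound 1 to compound 4 in this assay that is small, not beyond the scatter, in either direction: a 1.2-fold lower number from compound 1 to compound 4 (0.06 log units; within the scatter). For compound 4 the estimated dose in this assay is 10 mg/kg, with a range from 4 mg/kg to 25 mg/kg.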

Compound 4, dose for half-maximal effect: 54.3 mg/kg
The estimate for compound 4 lay 5.4-fold (0.73 log units) below the measured number; measured number above the stated range.
By their numbers in this assay, from the lowest: compounds 2 and 1 (each within the scatter of the next); then compounds 3 and 4 (each within the scatter of the next).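

In this assay, within the data shown here, the saturated chain carbon bound to an aromatic nitrogen proves sensitive to substitution: ethyl in place of hydrogen there gives a 4.7-fold higher number from compound 1 to compound 4 (0.67 log units; beyond the scatter) and so provides the first measured single-place step, one beyond the scatter. Read as methyl to propyl, the change moves the number upward, so at this place the longer chain needs more compound for the effect. No measurement on hand bears on the reason for this step.

One step cannot show whether the number climbs gradually with chain length or whether the rise belongs to propyl alone, which an ethyl or butyl chain at the same place would separate. Also open, from the compounds shown here alone, is how a branched isopropyl group, or a chain ending in an amine or a carboxylic acid, would behave there.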